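This account rests on a few compounds, and the source may have more. Where it says the series, first, only, none or still open, it means among the compounds named here.

Compound 2, with the structure `Nc1nc(NCCCc2ccccc2)nc(-c2c(F)cccc2CO)n1`, is measured in a functional assay on cells for positive allosteric modulation of G-protein coupled receptor 68 (Homo sapiens), read by a luciferase reporter and cAMP accumulation, with a stated time of 30 min, at pH 6.8 and pH 8.3, in the presence of a further agent that is not named here (a lower number here means a less potent compound, a higher number a more potent compound, by a factor of ten per unit of this negative logarithm), at 4.47. Among the three numbers seen so far it stands close to compound 1, whose structure is `Nc1nc(NCCCc2ccc(Oc3ccccc3)cc2)nc(-c2ccccc2CO)n1` and which in this assay gives 4.67, a gap within the scatter, and it stands clearly above compound 3, with the structure `Nc1nc(NCCCCc2ccccc2)nc(-c2c(F)cccc2CO)n1` and a value in this assay of 4.04. Among the compounds with values here, the only single-site step recorded, a number 0.43 log units lower from compound 2 to compound 3 (beyond the scatter), concerns the chain and not the change at hand. Compound 4, with the structure `Nc1nc(NCCCc2ccc(Oc3ccccc3)cc2)nc(-c2c(F)cccc2CO)n1`, arises from compound 2 through (phenoxy in place of hydrogen on an aromatic carbon). Within the data shown here, no measured step tests this change alone; compound 1 carries the phenoxy group but also lacks the fluorine, so its number is only a hint. An essentially flat step, a number 0.28 log units higher from compound 2 to compound 4 (within the scatter), is therefore expected, and compound 4 is estimated at 4.75, within 4.3 to 5.2.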

Compound 4, negative logarithm of the antagonist equilibrium constant: 4.94
Compound 4: middle estimate off by 0.19 log units, on the low side, within the range that was stated.
By their numbers in this assay, from the lowest: compound 3; then compounds 2, 1 and 4 (each within the scatter of the next, the first and the last beyond it).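

Within the data shown here, on the aromatic carbon para to a large group, phenoxy in place of hydrogen now has its own test in this assay and gives a number 0.47 log units higher from compound 2 to compound 4 (beyond the scatter), a modest gain that no earlier pair could isolate. Among these compounds, the fluoro group can also be read alone for the first time, and fluoro in place of hydrogen gives a number 0.27 log units higher from compound 1 to compound 4 (within the scatter), so no effect can be claimed for it. Nothing available explains either step. Still open, from the compounds shown here alone, is how an amine or a carboxylic acid in place of phenoxy on this carbon would compare, and whether phenoxy gives a similar step on the longer chain of compound 3.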